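The compounds below may be only part of what the source reports. "The series", "measured", "known", "first", "only" and "open" are said of these compounds alone.

In an in vitro ADME assay on microsomes from Gut (Homo sapiens) for metabolic stability, in the presence of a further agent that is not named here (on this read-out higher numbers stand for fast clearance and lower numbers for slow clearance), compound 1 (`CC(C)(CO)CNC(=O)c1cc2cc(C#N)ccc2n1Cc1cccc(OC(F)(F)F)c1`) gives 136 mL.min-1.g-1. Compound 2 (`COc1ccc(OC(F)(F)F)cc1Cn1c(C(=O)NCC(C)(C)CO)cc2cc(C#N)ccc21`) gives 68 mL.min-1.g-1 and compound 3 (`CCOc1ccc(OC(F)(F)F)cc1Cn1c(C(=O)NCC(C)(C)CO)cc2cc(C#N)ccc21`) gives 103 mL.min-1.g-1, so compound 1 stands within the scatter of both. Compound 4 (`CC(C)(O)CCNC(=O)c1cc2cc(C#N)ccc2n1Cc1cccc(OC(F)(F)F)c1`) keeps the core of compound 1 and alters only the amide chain: 2-hydroxy-2-methylpropyl in place of 1-(hydroxymethyl)-1-methylethyl on a saturated chain carbon bound to an amide-type nitrogen. Within the data shown here, no measured step touches this chain, as all three concern an aromatic substituent, so they bear on it only indirectly. They are a 2.0-fold lower number from compound 1 to compound 2 (0.30 log units; within the scatter), a 1.3-fold lower number from compound 1 to compound 3 (0.12 log units; within the scatter) and a 1.5-fold higher number from compound 2 to compound 3 (0.18 log units; within the scatter). With only these sizes to go on, no step beyond the scatter is expected in this assay, and no direction can be favoured. The estimated step is a 1.2-fold lower number from compound 1 to compound 4 (0.09 log units; within the scatter). For compound 4 the estimate is 110 mL.min-1.g-1, with an expected range of 55 mL.min-1.g-1 to 220 mL.min-1.g-1.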

Compound 4, intrinsic clearance in microsomes: 9 mL.min-1.g-1
Beside the measured number, compound 4's estimate is 12-fold (1.09 log units) above it; the whole stated range lies above it.
By their numbers in this assay, from the lowest: compound 4; then compounds 2, 3 and 1 (each within the scatter of the next).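

In this assay the amide chain proves a sensitive position: 2-hydroxy-2-methylpropyl in place of 1-(hydroxymethyl)-1-methylethyl, with the same atoms joined differently, gives a 15-fold lower number from compound 1 to compound 4 (1.18 log units; beyond the scatter). Among these compounds, the aromatic steps among compounds 1, 2 and 3 all stayed within the scatter, so this is the first step beyond it. Nothing available accounts for this step.

Open, from the compounds shown here alone, is whether the step carries over to the methoxy and ethoxy compounds 2 and 3. Also open, going by these compounds, is whether an amine, a carboxylic acid or a longer chain here would give a similar number.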